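The compounds below may be only part of what the source reports. "The series", "measured", "known", "first", "only" and "open" are said of these compounds alone.

Measured so far in an ADME assay on a cell-free system (plasma, Homo sapiens) for protein binding; a lower number here means a smaller unbound share, a higher number a larger unbound share of the compound:
compound 1, `COc1ccccc1C1CCN(c2ccn3c(CC4CC4)nnc3c2Cl)CC1`; in this assay compound 1 gives < 0.01.
compound 2, `COc1ccc(F)cc1C1CCN(c2ccn3c(CC4CC4)nnc3c2Cl)CC1`; in this assay compound 2 gives < 0.01.

The value of compound 1 is a limit of this assay, not a number. The value of compound 2 is likewise a limit, not a number. Among the compounds with values here, compound 2 therefore stands at the limit of < 0.01 in this assay, at which 2 of the 2 values shown sit, and the step that the two limits leave unreadable from compound 1 to compound 2 cannot be sized; the only measured change, a fluoro substitution on the aromatic ring, left the unbound fraction at the limit on both sides.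

Compound 3, `COc1c(F)ccc(F)c1C1CCN(c2ccn3c(CC4CC4)nnc3c2Cl)CC1`, differs from compound 2 by 3,6-difluoro-2-methoxyphenyl in place of 5-fluoro-2-methoxyphenyl on a saturated ring carbon. Within the data shown here, the one step measured so far bears on this change in kind but gives no size, since both ends of it sit at the limit. No step beyond the scatter can be argued from the data in either direction, and the working expectation is that compound 3 stays at the limit as well.

Compound 3 is estimated at 0.005, with a range from 0.002 to 0.012. The expected step for compound 3 is a step that the limit leaves unreadable from compound 2 to compound 3, which is no change beyond the scatter.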

Compound 3, unbound fraction: < 0.01
Compound 3 was reported as a limit (the forecaster's own chance of this, stated with the estimate: 85%); the middle value is on the limit's open side.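

Compound 3 gives < 0.01 in this assay as a limit and not a number, and the steps among compound 1, compound 2 and compound 3 cannot be read: the limit of < 0.01 in this assay, at which 3 of the 3 values shown sit.

The compounds shown leave open how large the unbound fraction of each of the three is, and whether the fluoro substitutions change it at all.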